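Swapping a trifluoromethyl amide for a ring-bearing amide

The compounds below may be only part of what the source reports. "The series", "measured", "known", "first", "only" and "open" are said of these compounds alone.

Of the compounds shown here, three have been tested so far in a functional assay on the whole organism (blood) with Rattus norvegicus as the target, with stated times of 24 h and 1 h, at a dose of 5 mg/kg by the intraperitoneal route; on this read-out higher numbers stand for a stronger effect at the one dose given and lower numbers for a weaker effect. Compound 1 `COc1ccc(Cl)cc1C(=O)NCCC1CCN(S(=O)(=O)NC(=O)NN2CCCCCC2)CC1` gives 36%, compound 2 `O=C(NC[C@@H]1C[C@@H]2C=C[C@@H]1C2)NS(=O)(=O)N1CCC(CCNC(=O)C(F)(F)F)CC1` gives 22%, and compound 3 `COc1ncccc1C(=O)NCCC1CCN(S(=O)(=O)NC(=O)NCC2CCCCO2)CC1` gives 12%. Among these, compound 2 holds the second highest number; its result sits within the usual scatter of the number for compound 3, so the two cannot be told apart, while compound 1 stands beyond the scatter above compound 2.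

The next compound, compound 4 `Cn1cc(C(=O)NCCC2CCN(S(=O)(=O)NC(=O)NC[C@@H]3C[C@@H]4C=C[C@@H]3C4)CC2)c(=O)n(C)c1=O`, differs from compound 2 in one place: a group of 10 heavy atoms (6 carbon, 2 nitrogen, 2 oxygen; one six-membered aromatic ring with 2 hetero atoms) in place of a group of 4 heavy atoms (1 carbon, 3 fluorine; no ring), on a carbonyl carbon. The other compounds carrying an aromatic amide at this position, compound 1 and compound 3, gave numbers spread on both sides of compound 2, so no direction can be read from them for this kind of change. The step from compound 2 to compound 4 is therefore expected to stay within the scatter, with a number 3 percentage points higher from compound 2 to compound 4 (within the scatter) as the estimate of that step. Compound 4 is expected to show about 25%, with a range from 8% to 45%.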

Compound 4, a percentage reported as activity, at one dose (the size of the read-out at that dose, not a potency): 23%
Beside the measured number, compound 4's estimate is 2 percentage points above it, within the range that was stated.
By their numbers in this assay, from the lowest: compounds 3, 2 and 4 (each within the scatter of the next, the first and the last beyond it); then compound 1.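

Among the compounds shown here, this pair gives the first direct reading of the group on the carbonyl carbon in this assay, since only this one place changes, and the swap amounts to a number 1 percentage points higher from compound 2 to compound 4 (within the scatter). The read-out therefore does not separate trifluoromethyl from the far larger group with its six-membered aromatic ring, although that group has 4 hydrogen-bond acceptors and trifluoromethyl has 0. So, for this pair, neither the added size nor the added acceptors shows up as a difference at the one dose given, and no measurement is at hand that would explain this result.

The higher number of compound 1 cannot be assigned to its amide, as that compound also differs elsewhere. On these data alone, whether a simple methyl group, an amine or a carboxylic acid-bearing chain on this carbonyl carbon would move the number remains open.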